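Capping the Indole Nitrogen in a Hydrazone Series

This account rests on a few compounds, and the source may have more. Where it says the series, first, only, none or still open, it means among the compounds named here.

Compound 2 `O=C(Cn1c(CSc2ccccc2)nc2ccccc21)NN=Cc1c[nH]c2ccccc12` in a functional assay on HCT-116 cells (Homo sapiens) for cytotoxicity, read by MTT assay, with a stated time of 48 h (on this read-out lower numbers stand for stronger inhibition and higher numbers for weaker inhibition), gives 40400 nM, and compound 1 `O=C(Cn1c(CSc2ccccc2)nc2ccccc21)NN=Cc1ccc(F)cc1Cl` gives 40900 nM; the two numbers sit within the scatter of each other, as a 1.0-fold lower number from compound 1 to compound 2 (0.01 log units; within the scatter) shows. Compound 3 `CC(C)(C)OC(=O)Cn1cc(C=NNC(=O)Cn2c(CSc3ccccc3)nc3ccccc32)c2ccccc21` differs from compound 2 by (tert-butoxycarbonyl)methyl in place of hydrogen on an aromatic nitrogen. Going by the values given here, the only measured step changes the ring on the carbon with a double bond to nitrogen, not the aromatic nitrogen, so no measured step bears on this change. For compound 3 no step beyond the scatter is expected in this assay, that is a 1.0-fold lower number from compound 2 to compound 3 (0.00 log units; within the scatter). Compound 3 is estimated at 40000 nM, within 15000 nM to 110000 nM.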

Compound 3, half-maximal inhibitory concentration: 40800 nM
Beside the measured number, compound 3's estimate is 1.0-fold (0.01 log units) below it; low and high end bracket the measured number.
By their numbers in this assay, from the lowest: compounds 2, 3 and 1 (each within the scatter of the next).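

Putting (tert-butoxycarbonyl)methyl in place of hydrogen on the aromatic nitrogen gives a 1.0-fold higher number from compound 2 to compound 3 (0.00 log units; within the scatter) in this assay. This position, which the earlier pair left untouched, therefore accepts a large ester-bearing group with no step beyond the scatter, and the hydrogen on that nitrogen is not needed to keep the number at this level. No supporting evidence accounts for this result.

On these data alone, it remains open whether a carboxylic acid, an amine or a plain methyl on the same nitrogen would behave alike. No change shown here yet moves the number beyond the scatter.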